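Swapping a hydroxyphenyl for a bromophenyl on the urea

The source may hold more compounds than are shown below. What is called first, only, known or untested is meant among the compounds shown, and "the series" means these compounds.

Measured so far:
compound 1 `COc1cc(NC(C)CCCNC(=O)Nc2ccc(C(F)(F)F)cc2)c2ncccc2c1` gives 8400 nM in a functional assay on MIA PaCa-2 cells (Homo sapiens) for inhibition, read by MTT assay, with a stated time of 72 h; on this read-out lower numbers stand for stronger inhibition and higher numbers for weaker inhibition
compound 2 `COc1cc(NC(C)CCCNC(=O)NNC(=O)Nc2cccc(Cl)c2)c2ncccc2c1` gives 74000 nM
compound 3 `COc1cc(NC(C)CCCNC(=O)Nc2cccc(O)c2)c2ncccc2c1` gives 46000 nM

Compound 3 stands second highest of the three numbers; its gap to compound 2 is within the scatter, while a 5.5-fold higher number from compound 1 to compound 3 (0.74 log units; beyond the scatter) lies beyond it. Compound 4 `COc1cc(NC(C)CCCNC(=O)Nc2ccc(Br)cc2)c2ncccc2c1` differs from compound 3 as follows: 4-bromophenyl in place of 3-hydroxyphenyl on an amide-type nitrogen. The step that bears on this is a 5.5-fold higher number from compound 1 to compound 3 (0.74 log units; beyond the scatter), which went the other way: from a group with no hydrogen-bond donor or acceptor to one with a donor and acceptor, and the number rose. Compound 4 returns to a group with none of either, so a lower number is expected, roughly undoing that step. Compound 4 is therefore estimated at 10000 nM, in the range 4000 nM to 30000 nM, the expected step being a 4.6-fold lower number from compound 3 to compound 4 (0.66 log units; beyond the scatter).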

Compound 4, half-maximal inhibitory concentration: 23000 nM
Beside the measured number, compound 4's estimate is 2.3-fold (0.36 log units) below it, within the range that was stated.
By their numbers in this assay, from the lowest: compound 1; then compounds 4, 3 and 2 (each within the scatter of the next, the first and the last beyond it).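

Replacing 3-hydroxyphenyl with 4-bromophenyl removes the hydrogen-bond donor and acceptor, yet the change stays small (a 2.0-fold lower number from compound 3 to compound 4 (0.30 log units; within the scatter)), and compound 4 does not reach the number of compound 1. The group on the aromatic carbon still matters, since bromo in place of trifluoromethyl gives a real step (a 2.7-fold higher number from compound 1 to compound 4 (0.44 log units; beyond the scatter)), as does 4-bromophenyl in place of ((3-chlorophenyl)carbamoyl)amino (a 3.2-fold lower number from compound 2 to compound 4 (0.51 log units; beyond the scatter)). Nothing available explains these steps.

Still open, going by these compounds, is how an amine or a carboxylic acid in place of the bromo would move the number.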